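The source may hold more compounds than are shown below. What is called first, only, known or untested is meant among the compounds shown, and "the series" means these compounds.

Working notes on the series in a functional assay on MCF7 cells (Homo sapiens) for antiproliferative activity, read by sulforhodamine B assay, with a stated time of 72 h; on this read-out lower numbers stand for stronger inhibition and higher numbers for weaker inhibition. Compound 1 (`S=C(NNc1nncc2ccccc12)Nc1ccccc1`) gives 47 nM and compound 2 (`O=S(=O)(Nc1ncccn1)c1ccc(Nc2nncc3ccccc23)cc1`) gives 64 nM, two values within the scatter of each other. Compound 3 (`Fc1ccc(Nc2nncc3ccccc23)cc1`) gives 3.5 nM, a number lower than that of compound 2 by a margin beyond the scatter. Compound 2 therefore stands in the upper pair of the three numbers, together with compound 1.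

Compound 4 (`Cc1cc(NS(=O)(=O)c2ccc(Nc3nncc4ccccc34)cc2)no1`) differs from compound 2 in one place: 5-methyl-1,2-oxazol-3-yl in place of pyrimidin-2-yl on a sulfonamide nitrogen. In words, this puts 5-methyl-1,2-oxazol-3-yl in place of pyrimidin-2-yl on a sulfonamide nitrogen. Going by the values given here, no measured pair shows a single change of this kind, so the size of the step has no direct precedent. Among the compounds with values here, the only anchor is compound 2 at 64 nM, and no shift beyond the scatter is expected in either direction. The expected step of a 1.2-fold lower number from compound 2 to compound 4 (0.07 log units; within the scatter) is therefore small. For compound 4 the estimated value is 55 nM, with an expected range of 18 nM to 170 nM.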

Compound 4, half-maximal inhibitory concentration: 46 nM
Estimate against measurement, compound 4: 1.2-fold (0.08 log units) above, within the range that was stated.
By their numbers in this assay, from the lowest: compound 3; then compounds 4, 1 and 2 (each within the scatter of the next).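

In this assay, going by these compounds alone, the one comparison that can be read in a single place gives a 1.4-fold lower number from compound 2 to compound 4 (0.14 log units; within the scatter), so this exchange on a sulfonamide nitrogen produces no change beyond the scatter. At this position, a five-membered aromatic ring carrying a methyl group therefore stands in for a six-membered aromatic ring with the same heavy-atom, donor and acceptor counts, without a readable change in the number. No measured information here accounts for this outcome.

Both groups compared are aromatic rings with two hetero atoms and no net charge, so the series leaves open how the number responds to an unsubstituted sulfonamide nitrogen, a plain phenyl ring, a longer alkyl chain or a carboxylic acid at this place. As far as these compounds go, it also remains open whether the same exchange gives a similar step on a different core.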